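The source may hold more compounds than are shown below. What is called first, only, known or untested is meant among the compounds shown, and "the series" means these compounds.

Measured in an ADME assay on HepG2 2.2.15 cells (Homo sapiens) for cytotoxicity, read by CCK-8 assay, with a stated time of 8 days; a higher number here means that more compound is tolerated, a lower number that less compound is tolerated:
- Compound 1 `CCOc1ccc(-n2cc(C(=O)c3ccc(OC)cc3O)ccc2=O)cc1`: > 100000 nM, a limit of the assay
- Compound 2 `Cc1cccc(-c2cc(NC(=O)c3ccccc3O)c[nH]c2=O)c1`: 98800 nM

Among the compounds with values here, compound 2 holds the only actual number in this assay so far, since the other entry is a limit. Compound 3 `Cc1cccc(-c2cc(NC(=O)c3ccc(C)cc3O)c[nH]c2=O)c1` differs from compound 2 by methyl in place of hydrogen on an aromatic carbon, with methyl in place of hydrogen on an aromatic carbon, turning 2-hydroxyphenyl into 2-hydroxy-4-methylphenyl. Within the data shown here, no step between measured compounds is available for comparison, so the expectation rests on compound 2 at 98800 nM alone. The expected 1.2-fold lower number from compound 2 to compound 3 (0.07 log units; within the scatter) is slightly downward and no larger than the usual scatter. The estimate for compound 3 is 85000 nM, with an expected range of 45000 nM to 100000 nM.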

Compound 3, half-maximal cytotoxic concentration: 75000 nM
For compound 3 the middle estimate is 1.1-fold (0.05 log units) above the measured one; low and high end bracket the measured number.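

In this assay, methyl in place of hydrogen on the aromatic carbon meta to the hydroxy group and para to a large group gives a 1.3-fold lower number from compound 2 to compound 3 (0.12 log units; within the scatter). This first one-place comparison therefore does not separate 2-hydroxy-4-methylphenyl from 2-hydroxyphenyl. Compound 1 is the entry held at a limit of this read-out: the limit of > 100000 nM in this assay, at which 1 of the 3 values shown sits.

A single small group at a single position has been read so far. On these data alone, how an amine, a carboxylic acid or a longer chain at this position would read remains open.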